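The source may hold more compounds than are shown below. What is called first, only, known or untested is meant among the compounds shown, and "the series" means these compounds.

Measured so far: compound 1 `Cc1nn(C2COC2)cc1Nc1nc(N)c2c(C#N)c(N3CCC[C@H]3C)n(C)c2n1`, 25 nM; compound 2 `Cc1c(Nc2nc(N)c3c(C#N)c(N4CCC[C@H]4C)n(C)c3n2)cnn1[C@H]1CCOC1`, 14 nM.

In an assay on isolated protein for inhibition of Leucine-rich repeat serine/threonine-protein kinase 2 variant G2019S (Homo sapiens), read by TR-FRET and LanthaScreen, with stated times of 50 min and 30 min, in the presence of a further agent that is not named here (on this read-out lower numbers stand for stronger inhibition and higher numbers for weaker inhibition), compound 2 gives the lowest of the two numbers, while compound 1 stands within the scatter of it, so no order between them can be drawn. Compound 3 `Cc1c(Nc2nc(N)c3c(C#N)c(N4CCC[C@H]4C)n(C)c3n2)cnn1[C@@H]1CCOC1` keeps every atom and bond of compound 2 and differs only in configuration: the two compounds have the same atoms and bonds and differ only in configuration as drawn: 1 of 2 stereo elements differ; a stereocentre at a saturated ring carbon is drawn S in compound 2 and R in compound 3. Within the data shown here, no step of this kind has been measured, so the expectation rests on the change alone. For compound 3 a modest weakening beyond the scatter is expected, with the direction itself uncertain, as an estimated step of a 2.5-fold higher number from compound 2 to compound 3 (0.40 log units; beyond the scatter). Compound 3 is therefore estimated at 35 nM, with a range from 8 nM to 200 nM.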

Compound 3, half-maximal inhibitory concentration: 12 nM
Compound 3: middle estimate off by 2.9-fold (0.46 log units), on the high side; the range from low to high includes it.
By their numbers in this assay, from the lowest: compounds 3, 2 and 1 (each within the scatter of the next, the first and the last beyond it).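

In this assay, turning the stereocentre at a saturated ring carbon from S to R gives a 1.2-fold lower number from compound 2 to compound 3 (0.07 log units; within the scatter), so neither configuration at this position can be placed ahead of the other. This is the first pair in the series to isolate a single change, and that change is purely one of configuration: the fact that compounds 2 and 3 differ only in the configuration as drawn

Open, on these data alone, is how the number responds when an amine or a carboxylic acid stands on this saturated ring. Also open is what the other stereo element contributes, as it is drawn the same in all the compounds shown.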